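The compounds below may be only part of what the source reports. "The series", "measured", "known", "first", "only" and "open" are said of these compounds alone.

Measured in a functional assay on HepG2 cells (Homo sapiens) for antiproliferative activity, read by XTT assay, with a stated time of 72 h; a lower number here means a stronger inhibitor, a higher number a weaker inhibitor:
- compound 1 `CNc1ncnc2c1c(-c1ccco1)cn2[C@@H]1O[C@H](CO)[C@@H](O)[C@H]1O`: 850 nM
- compound 2 `CNc1ncnc2c1c(-c1ccsc1)cn2[C@@H]1O[C@H](CO)[C@@H](O)[C@H]1O`: > 20000 nM (a limit)
- compound 3 `C#Cc1cn([C@@H]2O[C@H](CO)[C@@H](O)[C@H]2O)c2ncnc(NC)c12`: > 15000 nM (a limit)

Compound 3 has no number, only (the limit of > 15000 nM in this assay, at which 1 of the 3 values shown sits). Compound 4 `CNc1ncnc2c1c(I)cn2[C@@H]1O[C@H](CO)[C@@H](O)[C@H]1O` carries iodo in place of ethynyl on an aromatic carbon. Among the compounds with values here, no measured step involves iodo. The nearest evidence is an at least 17-fold higher number from compound 1 to compound 3 (1.24 log units; beyond the scatter) and an at least 23-fold higher number from compound 1 to compound 2 (1.37 log units; beyond the scatter), both large and both leading away from furan-2-yl, a group that compound 4 also lacks. In this assay, no step beyond the scatter is therefore expected, and the expected move is an at least 1.2-fold lower number from compound 3 to compound 4 (0.09 log units; that floor lies within the scatter). A limit is also a likely result. For compound 4, the estimated value is 12000 nM, with an expected range of 2500 nM to 40000 nM.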

Compound 4, half-maximal inhibitory concentration: > 20000 nM
Compound 4 was reported as a limit; the forecaster's own chance of this, stated with the estimate: 60%; middle value at least 1.6-fold (0.22 log units) from the limit.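

In this assay, iodo in place of furan-2-yl on this aromatic carbon gives an at least 23-fold higher number from compound 1 to compound 4 (1.37 log units; beyond the scatter), so a single atom, like the two carbon groups before it, fails to keep the activity of compound 1. Compound 4 is reported only as a limit: the limit of > 20000 nM in this assay, at which 2 of the 4 values shown sit. The steps among compound 2, compound 3 and compound 4 all join limits and cannot be read.

Furan-2-yl thus remains the only group here with a measured number. The compounds shown leave open whether thiophen-2-yl, furan-3-yl, phenyl or an amine on this carbon would keep that activity.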